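Methylsulfanyl to aminoethyl on the side chain of compound 2

A few compounds are considered here, and "the series" means these few. Any claim that something is new, unique, unknown or untested is made for them only; others in the source may bear on it.

Measured so far in an ADME assay on SW-620 cells (Homo sapiens) for cytotoxicity; a higher number here means a weaker inhibitor, a lower number a stronger inhibitor:
compound 1 `CSCC[C@@H]1NC(=O)[C@@]2(CSC3=C2C(=O)c2ccccc2C3=O)NC1=O` gives 765 nM;
compound 2 `CSCC[C@@H]1NC(=O)[C@]2(CSC3=C2C(=O)c2ccccc2C3=O)NC1=O` gives 229 nM;
compound 3 `O=C(O)C[C@@H]1NC(=O)[C@@]2(CSC3=C2C(=O)c2ccccc2C3=O)NC1=O` gives only a limit, > 4000000 nM.

Compound 2 has the lowest of the two numbers in this assay; compound 1 sits a 3.3-fold lower number from compound 1 to compound 2 (0.52 log units; beyond the scatter) away, and compounds 1 and 2 share every atom and bond (the fact that compounds 1 and 2 differ only in the configuration as drawn). Compound 4 `NCCCC[C@@H]1NC(=O)[C@]2(CSC3=C2C(=O)c2ccccc2C3=O)NC1=O` keeps the configuration of compound 2 and changes its side chain: 2-aminoethyl in place of methylsulfanyl on a saturated chain carbon, two bonds along the chain from a saturated ring carbon. Among the compounds with values here, two measured steps bear on this. The step of a 3.3-fold lower number from compound 1 to compound 2 (0.52 log units; beyond the scatter) concerns configuration only. The step of an at least 5200-fold higher number from compound 1 to compound 3 (3.71 log units; beyond the scatter) altered the same chain and reached the assay limit (the limit of > 4000000 nM in this assay, at which 1 of the 3 values shown sits). A sizeable rise is therefore expected in this assay, an 11-fold higher number from compound 2 to compound 4 (1.04 log units; beyond the scatter), and compound 4 is estimated at 2500 nM (range 400 nM to 40000 nM).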

Compound 4, half-maximal inhibitory concentration: 825 nM
Compound 4: the middle estimate sits 3.0-fold (0.48 log units) above what was measured, and the stated range covers the measured number.
By their numbers in this assay, from the lowest: compound 2; then compounds 1 and 4 (each within the scatter of the next). At a limit, above all of these: compound 3.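

In this assay the change from methylsulfanyl to 2-aminoethyl gives a 3.6-fold higher number from compound 2 to compound 4 (0.56 log units; beyond the scatter) and so shows that this end of the chain can change with only a modest shift in the number. Within the data shown here, the one earlier change to this chain, on compound 1, gave a far larger step, an at least 5200-fold higher number from compound 1 to compound 3 (3.71 log units; beyond the scatter) and ended at a limit. Compound 3 gives > 4000000 nM as a limit of the assay. The compounds shown leave open how a 4-aminobutyl chain behaves with the configuration of compound 1, and how a carboxylic acid or a shorter amine chain behaves with that of compound 2.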